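Methoxy for chloro on the benzyl group of compound 3

The source may hold more compounds than are shown below. What is called first, only, known or untested is meant among the compounds shown, and "the series" means these compounds.

Measured so far in a functional assay on MIA PaCa-2 cells (Homo sapiens) for cytotoxicity, read by WST assay, with a stated time of 48 h; on this read-out lower numbers stand for stronger inhibition and higher numbers for weaker inhibition:
- compound 1 (`N#C/C(=C\c1cn(Cc2ccc(Cl)cc2)c2ccccc12)C(=O)c1c[nH]c2cc(F)ccc12`) gives 16600 nM
- compound 2 (`COc1ccc2c(C(=O)/C(C#N)=C/c3cn(Cc4ccc(Cl)cc4)c4ccccc34)c[nH]c2c1`) gives 40400 nM
- compound 3 (`N#C/C(=C\c1cn(Cc2ccc(Cl)cc2)c2ccccc12)C(=O)c1c[nH]c2ccccc12`) gives > 50000 nM as a limit of the assay, not a number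

Compound 3 has no number on this read-out, only a limit (the limit of > 50000 nM in this assay, at which 1 of the 3 values shown sits).

Compound 4 (`COc1ccc(Cn2cc(/C=C(\C#N)C(=O)c3c[nH]c4ccccc34)c3ccccc32)cc1`) differs from compound 3 in one place, 4-chlorobenzyl to 4-methoxybenzyl (methoxy in place of chloro on an aromatic carbon). This puts methoxy in place of chloro on an aromatic carbon, para to a large group.

Going by the values given here, no measured step touches this group, so the evidence is indirect and comes from changes elsewhere in the molecule. There, methoxy in place of fluoro gave a 2.4-fold higher number from compound 1 to compound 2 (0.39 log units; beyond the scatter) and hydrogen in place of fluoro gave an at least 3.0-fold higher number from compound 1 to compound 3 (0.47 log units; beyond the scatter). Hydrogen in place of methoxy gave an at least 1.2-fold higher number from compound 2 to compound 3 (0.09 log units; that floor lies within the scatter). Steps in this series are therefore modest so far, and a modest step at most is expected here. Any measurable change from a compound at the limit would have to run towards a lower number, and a second limit remains quite possible.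

The step expected is an at least 1.2-fold lower number from compound 3 to compound 4 (0.09 log units; that floor lies within the scatter) (an estimate only). The expected value for compound 4 is 40000 nM (estimated range 15000 nM to 80000 nM).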

Compound 4, half-maximal inhibitory concentration: > 50000 nM
Compound 4: a limit, no number; the forecaster's own chance of this, stated with the estimate: 50%; middle value at least 1.2-fold (0.09 log units) away from the limit.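

In this assay compound 4 gives > 50000 nM, a limit of the assay and not a number. Compound 3 also stands at a limit, so no step between compound 3 and compound 4 can be read: the limit of > 50000 nM in this assay, at which 2 of the 4 values shown sit.

The compounds shown leave open whether 4-chlorobenzyl and 4-methoxybenzyl differ at all in this assay.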